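A Halogenated Aniline in Place of a Methylated One

The source may hold more compounds than are shown below. What is called first, only, known or untested is meant among the compounds shown, and "the series" means these compounds.

Compound 1 `CC(=O)N1CCN(c2ccc(Nc3ncc(C(F)(F)F)c(N4Cc5cccc(N(C)S(C)(=O)=O)c5C4)n3)cc2)CC1`: 1300 nM
Compound 2 `Cc1cc(F)ccc1Nc1ncc(C(F)(F)F)c(N2Cc3cccc(N(C)S(C)(=O)=O)c3C2)n1`: > 30000 nM
Compound 3 `CN(c1cccc2c1CN(c1nc(Nc3cccc(Oc4ccccc4)c3)ncc1C(F)(F)F)C2)S(C)(=O)=O`: 19000 nM

In a functional assay on A549 cells (Homo sapiens) for antiproliferative activity, read by spectrophotometry, with a stated time of 2 days (a lower number here means a stronger inhibitor of growth, a higher number a weaker inhibitor of growth), compound 2 stands at > 30000 nM, which is a limit of the assay and not a number. The other two compounds give numbers: compound 1 gives 1300 nM, and compound 3 gives 19000 nM.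

Compound 4 `CN(c1cccc2c1CN(c1nc(Nc3ccc(Cl)c(C(F)(F)F)c3)ncc1C(F)(F)F)C2)S(C)(=O)=O` has 4-chloro-3-(trifluoromethyl)phenyl in place of the 4-fluoro-2-methylphenyl of compound 2, on a nitrogen on an aromatic ring (4-chloro-3-(trifluoromethyl)phenyl in place of 4-fluoro-2-methylphenyl on a nitrogen on an aromatic ring). For the measured compounds named here, no measured step bears directly on this change, so the expectation rests loosely on compound 3 at 19000 nM. The expected change is an at least 3.0-fold lower number from compound 2 to compound 4 (0.47 log units; beyond the scatter), a modest one toward stronger inhibition of growth. Compound 4 is estimated at 10000 nM, with an expected range of 3000 nM to 30000 nM.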

Compound 4, concentration for 50% growth inhibition: 15200 nM
Compound 4: the middle estimate sits 1.5-fold (0.18 log units) below what was measured, within the range that was stated.
By their numbers in this assay, from the lowest: compound 1; then compounds 4 and 3 (each within the scatter of the next). At a limit, above all of these: compound 2.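

With 4-chloro-3-(trifluoromethyl)phenyl on a nitrogen on an aromatic ring, compound 4 gives a measured number in this assay, where the 4-fluoro-2-methylphenyl of compound 2 gave only a limit. The change reads as an at least 1.9-fold lower number from compound 2 to compound 4 (0.29 log units; that floor lies within the scatter). That size is only a floor, because the value of compound 2 is a limit of the assay and not a number: the limit of > 30000 nM in this assay, at which 1 of the 4 values shown sits.

The compounds shown leave open whether the chlorine or the trifluoromethyl alone would carry this step. They also leave open how a morpholine or a carboxylic acid on this phenyl ring would read in this assay.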